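From 1H-pyrazol-4-yl to a six-membered non-aromatic ring

A few compounds are considered here, and "the series" means these few. Any claim that something is new, unique, unknown or untested is made for them only; others in the source may bear on it.

compound 1 `Cc1cc2ncccc2cc1C(C)n1cnc2ncc(-c3cnn(C)c3)nc21`: "not determined" (no result reported)
compound 2 `Cn1nccc1-c1cnc2ncn(Cc3ccc4ncccc4c3)c2n1`: 7910 nM
compound 3 `CC(NC/N=C/c1cn[nH]c1)c1ccc2ncccc2c1`: 519 nM

In a functional assay on NCI-H1993 cells (Homo sapiens) for inhibition, read by CCK-8 assay, with a stated time of 72 h (a higher number here means a weaker inhibitor, a lower number a stronger inhibitor), compound 3 gives 519 nM, the lower of the two numbers available. Compound 2 gives 7910 nM. The gap between these two compounds lies beyond the scatter. Compound 1 has no number to compare. Compound 4 `CC(NC/N=C/C1=CCNCC1)c1ccc2ncccc2c1` has not yet been measured. It differs from compound 3 by a group of 6 heavy atoms (5 carbon, 1 nitrogen; one six-membered non-aromatic ring with 1 hetero atom) in place of a group of 5 heavy atoms (3 carbon, 2 nitrogen; one five-membered aromatic ring with 2 hetero atoms), on a carbon with a double bond to nitrogen. Among the measured compounds shown here, no measured pair shows a change at this place, so the expectation rests on compound 3 at 519 nM and on the structural change alone. A modest step towards a higher number, meaning a weaker inhibitor, is expected. The expected step is a 2.5-fold higher number from compound 3 to compound 4 (0.40 log units; beyond the scatter). For compound 4 the estimated value is 1300 nM, with an expected range from 300 nM to 5500 nM.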

Compound 4, half-maximal inhibitory concentration: 2660 nM
Estimate against measurement, compound 4: 2.0-fold (0.31 log units) below, and the stated range covers the measured number.
By their numbers in this assay, from the lowest: compound 3; then compound 4; then compound 2.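

In this assay, among the compounds shown here, the first change at this carbon with a double bond to nitrogen gives a 5.1-fold higher number from compound 3 to compound 4 (0.71 log units; beyond the scatter), so here the six-membered non-aromatic ring does not match 1H-pyrazol-4-yl. This loss appears although the counted hydrogen-bond donor and acceptor and the absence of net charge stay the same. Nothing measured here explains the step. The compounds shown leave open how a phenyl ring, a saturated piperidine ring or an open-chain amine would read at this place, and this single pair cannot show whether the step holds elsewhere.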